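From methylsulfanyl to 1,3-thiazol-2-yl on a shared core

This account rests on a few compounds, and the source may have more. Where it says the series, first, only, none or still open, it means among the compounds named here.

Measured in a physicochemical assay for solubility, in phosphate buffer, with a stated time of 18 h; on this read-out higher numbers stand for higher solubility and lower numbers for lower solubility:
compound 1 `CC(C)(C)c1ccc2c(N)c(C#N)c(N)nc2n1`: 14200 nM
compound 2 `CSc1nc(C(C)(C)C)nc2nc(N)c(C#N)c(N)c12`: 14000 nM

Compound 2 stands level with compound 1, since their two numbers lie within the scatter of each other. Nothing in these numbers separates the pair.

The next compound, compound 3 `CC(C)(C)c1nc(-c2nccs2)c2c(N)c(C#N)c(N)nc2n1`, has not yet been measured. It carries 1,3-thiazol-2-yl in place of methylsulfanyl on an aromatic carbon, next to the ring nitrogen: 1,3-thiazol-2-yl in place of methylsulfanyl on an aromatic carbon. Among the compounds with values here, the data hold no measured step of this kind, so any expectation remains loose. A moderate fall in this assay is expected, starting from compound 2 at 14000 nM. The estimated change is a 2.3-fold lower number from compound 2 to compound 3 (0.37 log units; beyond the scatter). For compound 3 the expected value is 6000 nM, with an estimated range from 1800 nM to 16000 nM.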

Compound 3, solubility: < 1500 nM
Compound 3 gave a limit, no number (the forecaster's own chance of this, stated with the estimate: 10%); at least 4.0-fold (0.60 log units) between middle value and limit.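

Compound 3 gives no number in this assay, only a limit of that assay: the limit of < 1500 nM in this assay, at which 1 of the 3 values shown sits. Even so, with 1,3-thiazol-2-yl in place of methylsulfanyl on an aromatic carbon, next to the ring nitrogen, the read-out shows an at least 9.3-fold lower number from compound 2 to compound 3 (0.97 log units; beyond the scatter). Within the data shown here, the earlier compounds offered no step in one place at all, so this is the first sign that the read-out responds to what sits at this position.

As far as these compounds go, how far compound 3 lies past its limit stays open, and with it the full size of the step. Whether the aromatic ring itself matters, and whether an amine or a methoxy group on this carbon would keep the read-out near that of compound 2, the compounds shown do not tell.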